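The source may hold more compounds than are shown below. What is called first, only, known or untested is meant among the compounds shown, and "the series" means these compounds.

Compound 1 `CCc1ccc2oc(CSc3nnc(CNc4ccccc4)n3CC)nc2c1`: in an assay on isolated protein for inhibition of long-chain fatty acid transport protein 1 (Homo sapiens) (a lower number here means a stronger inhibitor, a higher number a weaker inhibitor), compound 1 gives > 1000 nM, which is a limit of the assay.
Compound 2 `CC/C(=N/OC)c1ccc2oc(CSc3nnc(CNc4ccccc4)n3CC)nc2c1`: compound 2 gives > 1000 nM, again a limit.
Compound 3 `CCn1c(CNc2ccccc2)nnc1SCc1nc2cc(C)ccc2o1`: compound 3 gives > 1000 nM, also a limit.

Among the measured compounds shown here, compound 3 therefore stands where every value so far stands, at the limit of > 1000 nM in this assay, at which 3 of the 3 values shown sit. Compound 4 `CCn1c(CNc2ccccc2)nnc1SCc1nc2cc(OC(F)(F)F)ccc2o1` differs from compound 3 in one place: trifluoromethoxy in place of methyl on an aromatic carbon. Three measured steps could bear on this change, a step that the two limits leave unreadable from compound 1 to compound 2, a step that the two limits leave unreadable from compound 1 to compound 3 and a step that the two limits leave unreadable from compound 2 to compound 3, but none of them has a readable size because all three values sit at the limit of > 1000 nM in this assay, at which 3 of the 3 values shown sit. Nothing in these data points to a change that would carry compound 4 past the limit. Compound 4 is therefore expected to stay at the limit, with an estimate of 2000 nM and a range from 700 nM to 6000 nM. The expected step from compound 3 to compound 4 is a step that the limit leaves unreadable from compound 3 to compound 4.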

Compound 4, half-maximal inhibitory concentration: 100 nM
The estimate for compound 4 lay 20-fold (1.30 log units) above the measured number, outside the stated range (below it).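

In this assay, among the compounds shown here, this place on the six-membered aromatic ring is the first to show a readable effect, as trifluoromethoxy in place of methyl gives an at least 10-fold lower number from compound 3 to compound 4 (1.00 log units; beyond the scatter) and trifluoromethoxy in place of ethyl gives an at least 10-fold lower number from compound 1 to compound 4 (1.00 log units; beyond the scatter). Against the larger group of compound 2, the same place gives an at least 10-fold lower number from compound 2 to compound 4 (1.00 log units; beyond the scatter). The group at this one place can therefore separate a compound with a readable number from those at the limit: the limit of > 1000 nM in this assay, at which 3 of the 4 values shown sit.

The compounds shown leave open whether the oxygen or the fluorines matter more. A methoxy or trifluoromethyl group here would separate the two.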